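This account rests on a few compounds, and the source may have more. Where it says the series, first, only, none or still open, it means among the compounds named here.

Of the compounds shown here, three have been measured in an ADME assay on NIH3T3 cells (Mus musculus) for cytotoxicity, read by MTT assay, with a stated time of 24 h; a lower number here means a stronger inhibitor, a higher number a weaker inhibitor. Compound 1 `O=C(CN1CCN(c2ccc(Cl)cc2)CC1)N1CCN(c2nnc(-c3ccccc3)c(-c3ccccc3)n2)CC1` gives 113000 nM in this assay. For compound 2 `COc1cccc(N2CCN(CC(=O)N3CCN(c4nnc(-c5ccc(C)cc5)c(-c5ccc(C)cc5)n4)CC3)CC2)c1` only a limit of the assay is recorded, > 866000 nM (the limit of > 866000 nM in this assay, at which 1 of the 3 values shown sits). Compound 3 `COc1ccc(-c2nnc(N3CCN(C(=O)CN4CCN(c5ccccc5OC)CC4)CC3)nc2-c2ccc(OC)cc2)cc1` likewise reaches only a limit of the assay, > 821000 nM (the limit of > 821000 nM in this assay, at which 1 of the 3 values shown sits), so its place on the numbers is known only as that limit, and one further value shown is also a limit. Compound 4 `COc1ccc(-c2nnc(N3CCN(C(=O)CN4CCN(c5ccc(OC)cc5)CC4)CC3)nc2-c2ccc(OC)cc2)cc1` is the next compound, and it differs from compound 3 by 4-methoxyphenyl in place of 2-methoxyphenyl on an amine nitrogen in a ring. For the measured compounds named here, no step between measured compounds is available to guide the size of this change; the step of an at least 1.0-fold lower number from compound 3 to compound 4 (0.01 log units; that floor lies within the scatter) is expected to stay within the scatter. Compound 4 is expected to give about 800000 nM, between 200000 nM and 1500000 nM, most probably again reported as a limit.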

Compound 4, half-maximal inhibitory concentration: > 821000 nM
Compound 4: only a limit was reported (the forecaster's own chance of this, stated with the estimate: 70%); middle value at least 1.0-fold (0.01 log units) away from the limit.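

For the compounds shown here, compound 3 and compound 4 are both recorded only as limits of the assay, so no step between them can be read. The compounds shown leave open whether 4-methoxyphenyl and 2-methoxyphenyl differ here at all.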